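Aryl-tetrazole series: amino-pyridyl replacement at the aryl position

The compounds below may be only part of what the source reports. "The series", "measured", "known", "first", "only" and "open" are said of these compounds alone.

Measured so far in an assay for binding affinity to metabotropic glutamate receptor 5 (Rattus norvegicus); on this read-out lower numbers stand for stronger inhibition and higher numbers for weaker inhibition:
compound 1 `Cc1ccccc1-c1cc(F)cc(-n2nnc(-c3ccccn3)n2)c1` 23 nM
compound 2 `N#Cc1ccccc1-c1cc(F)cc(-n2nnc(-c3ccccn3)n2)c1` 4 nM
compound 3 `Cc1cncc(-c2cc(F)cc(-n3nnc(-c4ccccn4)n3)c2)c1` 272 nM

Compound 3 gives the highest number of the three; its nearest neighbour is compound 1 at a 12-fold higher number from compound 1 to compound 3 (1.07 log units; beyond the scatter) and its furthest is compound 2 at a 68-fold higher number from compound 2 to compound 3 (1.83 log units; beyond the scatter). The cyano for methyl swap, a 5.8-fold lower number from compound 1 to compound 2 (0.76 log units; beyond the scatter), lies apart from the position in question.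

Compound 4 `Nc1cccnc1-c1cc(F)cc(-n2nnc(-c3ccccn3)n2)c1` is not yet measured. The change from compound 3 is 3-aminopyridin-2-yl in place of 5-methylpyridin-3-yl on an aromatic carbon. Among the measured compounds shown here, only the two steps into compound 3 touch this position, and both were large; no measured step exchanges a methyl for an amino group or shifts the ring nitrogen. The expectation for this assay is therefore a lower number than compound 3, of uncertain size, estimated as a 4.5-fold lower number from compound 3 to compound 4 (0.66 log units; beyond the scatter). Compound 4 is expected near 60 nM, within 15 nM to 250 nM.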

Compound 4, inhibition constant: 31 nM
For compound 4 the middle estimate is 1.9-fold (0.29 log units) above the measured one, within the range that was stated.
By their numbers in this assay, from the lowest: compound 2; then compounds 1 and 4 (each within the scatter of the next); then compound 3.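

In this assay a pyridine ring at this position need not cost binding: the 3-aminopyridin-2-yl group gives an 8.8-fold lower number from compound 3 to compound 4 (0.94 log units; beyond the scatter) and so recovers most of the loss seen with the 5-methylpyridin-3-yl group. Against the 2-methylphenyl group it shows a 1.3-fold higher number from compound 1 to compound 4 (0.13 log units; within the scatter) and against the 2-cyanophenyl group it shows a 7.8-fold higher number from compound 2 to compound 4 (0.89 log units; beyond the scatter) so the nitrile-bearing ring keeps its lead. No available evidence explains these differences.

Compound 4 changes the amino group and the ring nitrogen placement together, so their separate contributions stay unresolved. Also open, going by these compounds, is what a hydroxyl or dimethylamino group would give in place of the amino group.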